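Aryl exchange on a saturated ring carbon: compound 4

A few compounds are considered here, and "the series" means these few. Any claim that something is new, unique, unknown or untested is made for them only; others in the source may bear on it.

Measured so far, in a functional assay on PPC-1 cells (Homo sapiens) for antiproliferative activity, read by sulforhodamine B assay; a lower number here means a stronger inhibitor, a higher number a weaker inhibitor:
compound 1 `CCCCCCCCCCCCCCCCCCNC(=O)[C@H]1CSC(CCCCCCCCCCCC)N1` gives 13000 nM
compound 2 `CCCCCCCCCCCCCCCCCCNC(=O)[C@H]1CSC(c2ccc(N(C)C)cc2)N1` gives 1100 nM
compound 3 `CCCCCCCCCCCCCCCCCCNC(=O)[C@H]1CSC(c2cccc(O)c2)N1` gives 1200 nM

Compound 3 stands second highest of the three numbers in this assay. The gap a 1.1-fold higher number from compound 2 to compound 3 (0.04 log units; within the scatter) lies within the scatter, so no order between these two can be read; the gap an 11-fold lower number from compound 1 to compound 3 (1.03 log units; beyond the scatter) lies well beyond it.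

Compound 4 `CCCCCCCCCCCCCCCCCCNC(=O)[C@H]1CSC(c2ccc([N+](=O)[O-])cc2)N1` is not yet measured. The change from compound 3 is 4-nitrophenyl in place of 3-hydroxyphenyl on a saturated ring carbon.

Two of the measured steps concern the same position. The steps of a 12-fold lower number from compound 1 to compound 2 (1.07 log units; beyond the scatter) and an 11-fold lower number from compound 1 to compound 3 (1.03 log units; beyond the scatter) show that an aromatic ring in place of the dodecyl chain on that saturated ring carbon lowers the number strongly, whatever the substituent on the ring. The step of a 1.1-fold higher number from compound 2 to compound 3 (0.04 log units; within the scatter) shows that exchanging one substituted aromatic ring for another left the number within the scatter. Going by the values given here, the move to compound 4 is again an exchange of one substituted aromatic ring for another; a nitro group has no precedent, so this remains the only guide.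

For compound 4 the expected step is therefore no change at the digits printed from compound 3 to compound 4 (within the scatter), none beyond the scatter. Compound 4 is estimated at 1200 nM in this assay, within 400 nM to 3600 nM.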

Compound 4, half-maximal inhibitory concentration: 15300 nM
Beside the measured number, compound 4's estimate is 13-fold (1.11 log units) below it; measured number outside the range, above it.
By their numbers in this assay, from the lowest: compounds 2 and 3 (each within the scatter of the next); then compounds 1 and 4 (each within the scatter of the next).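

An aromatic ring on this saturated ring carbon does not bring the lower number by itself: 4-nitrophenyl in place of dodecyl gives no change that can be read in this assay (a 1.2-fold higher number from compound 1 to compound 4 (0.07 log units; within the scatter)), so compound 4 goes against the gain seen with compound 2 and compound 3. The substituent on the ring therefore matters here, although the earlier exchange between rings suggested otherwise: nitro in place of dimethylamino, a change in one place on an aromatic carbon, gives a large step (a 14-fold higher number from compound 2 to compound 4 (1.14 log units; beyond the scatter)), and 4-nitrophenyl in place of 3-hydroxyphenyl gives one of similar size (a 13-fold higher number from compound 3 to compound 4 (1.11 log units; beyond the scatter)). Nothing measured here accounts for the effect of the nitro group.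

From the compounds shown here alone, whether the loss is specific to nitro stays open: an amine or a methoxy group on the same aromatic carbon would show how the number follows the group at that site. The pair of 3-hydroxyphenyl and 4-nitrophenyl changes both the group and where it sits on the aromatic ring, so it cannot separate these two changes.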